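A benzyl-to-phenyl swap at the growth limit

The compounds below may be only part of what the source reports. "The series", "measured", "known", "first", "only" and "open" are said of these compounds alone.

Compound 1 `Cc1ccccc1Nc1nc(NC2CCCCC2)ncc1Cl`: > 100000 nM
Compound 2 `CCN1CCN(c2ccc(Nc3ncc(Cl)c(Nc4ccccc4C)n3)cc2)CC1`: 2060 nM
Compound 3 `CN1CCN(c2ccc(Nc3ncc(Cl)c(NCc4ccc(F)cc4)n3)nc2)CC1`: > 100000 nM

All three compounds were tested in a functional assay on Jurkat cells (Homo sapiens) for inhibition, read by CCK-8 assay, with a stated time of 48 h; on this read-out lower numbers stand for stronger inhibition of growth and higher numbers for weaker inhibition of growth. Compound 3 stands at the limit of > 100000 nM in this assay, at which 2 of the 3 values shown sit. Its entry is a limit and not a number. Compound 1 also gives only a limit. Only compound 2 gives a number, 2060 nM.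

Compound 4 `CC(C)c1ccc(Nc2nc(Nc3ccc(N4CCN(C)CC4)cn3)ncc2Cl)cc1` has not yet been measured. Its change from compound 3 is 4-isopropylphenyl in place of 4-fluorobenzyl on a nitrogen on an aromatic ring. Thus 4-isopropylphenyl replaces 4-fluorobenzyl on a nitrogen on an aromatic ring.

No measured pair sizes this change directly. The expectation rests on compound 2, which has no benzyl group and gives 2060 nM. Compound 1 goes against this reading, since it has no benzyl group either. In this assay a large step toward stronger inhibition of growth is therefore expected, though with wide uncertainty. The estimated change is an at least 25-fold lower number from compound 3 to compound 4 (1.39 log units; beyond the scatter). For compound 4 the estimated value is 4000 nM, with an expected range from 700 nM to 40000 nM.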

Compound 4, concentration for 50% growth inhibition: 7530 nM
The estimate for compound 4 lay 1.9-fold (0.27 log units) below the measured number, and the stated range covers the measured number.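

In this assay, the replacement on a nitrogen on an aromatic ring gives an at least 13-fold lower number from compound 3 to compound 4 (1.12 log units; beyond the scatter), the first measured pair showing that a change at this one place can take a compound off the limit and yield a number. With the rest of the structure held constant, the (4-fluorobenzyl)amino to (4-isopropylphenyl)amino change alone separates a limit from a measurable inhibition of growth. The full size of the step remains unknown, since the entry for compound 3 is a limit and not a number: the limit of > 100000 nM in this assay, at which 2 of the 4 values shown sit.

The compounds shown leave open whether the step follows from losing the benzyl link or from isopropyl standing in place of fluorine, which a 4-fluorophenyl or a 4-isopropylbenzyl group would separate. They also leave open how an amine or a carboxylic acid in place of the isopropyl would read.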